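Hydrogen for Methyl on an Aromatic Oxygen

The compounds below may be only part of what the source reports. "The series", "measured", "known", "first", "only" and "open" are said of these compounds alone.

Compound 1 `CCc1cc2c(C(=O)c3ccc(OC)cc3)cc(OC)cc2o1` gives 1.5%
Compound 2 `CCc1cc2c(C(=O)c3ccc(OC)cc3)ccc(OC)c2o1` gives 7.4%

In an assay for inhibition of solute carrier family 22 member 12 (Homo sapiens), read by scintillation counting, with a stated time of 60 min, tested at 50 uM (a lower number here means less inhibition, a higher number more inhibition at the concentration tested (going by the name of the read-out)), compound 1 gives 1.5% and compound 2 gives 7.4%; these two numbers lie within the scatter of each other, so neither stands apart. Compound 3 `CCc1cc2c(C(=O)c3ccc(OC)cc3)ccc(O)c2o1` differs from compound 2 by hydrogen in place of methyl on an oxygen on an aromatic ring. Going by the values given here, no measured pair shows this change, so there is no step to lean on. Both measured numbers are low, and a move from compound 2 to compound 3 beyond the scatter is not expected in either direction. Compound 3 is estimated at 9% in this assay, with a range of 0% to 28%, which means an expected step of a number 1.6 percentage points higher from compound 2 to compound 3 (within the scatter).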

Compound 3, a percentage reported as inhibition, at one concentration (the size of the read-out at that concentration, not a potency): 0.8%
Compound 3: the middle estimate sits 8.2 percentage points above what was measured, and the stated range covers the measured number.
By their numbers in this assay, from the lowest: compounds 3, 1 and 2 (each within the scatter of the next).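

In this assay, going by these compounds alone, the exchange of methoxy for hydroxy gives a number 6.6 percentage points lower from compound 2 to compound 3 (within the scatter) and so adds the first measured step at this oxygen on an aromatic ring. Removing the methyl here does not carry the number beyond the usual scatter, and the three compounds still cannot be put in order. No measured evidence bears on what lies behind this result.

Still open, going by these compounds, is whether a longer chain on this oxygen would give a number beyond the scatter. The same question stands for a group ending in an amine or a carboxylic acid.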